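A few compounds are considered here, and "the series" means these few. Any claim that something is new, unique, unknown or untested is made for them only; others in the source may bear on it.

Values in a functional assay on Bel-7402 cells (Homo sapiens) for inhibition, read by MTT assay, with a stated time of 72 h; on this read-out lower numbers stand for stronger inhibition and higher numbers for weaker inhibition:
- compound 1 `Nc1ncnc2c1c(-c1cnc3[nH]ccc3c1)nn2CCCCCCCCC(=O)NO`: 18900 nM
- compound 2 `Nc1ncnc2c1c(-c1cnc3[nH]ccc3c1)nn2CCCCCC(=O)NO`: "not determined" (no result reported)
- compound 3 `Nc1ncnc2c1c(-c1cnc3[nH]ccc3c1)nn2CCCCCCC(=O)NO`: 30800 nM

Among the compounds with values here, only two numbers are available in this assay, and they lie within the scatter of each other: a 1.6-fold higher number from compound 1 to compound 3 (0.21 log units; within the scatter). Within the data shown here, compound 1 therefore stands level with the only other measured compound, and compound 2 adds no number.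

Compound 4 `Nc1nc2cc(-c3nn(CCCCCCCCC(=O)NO)c4ncnc(N)c34)ccc2o1` keeps the chain of compound 1 and exchanges the aromatic group on the shared core: a group of 10 heavy atoms (7 carbon, 2 nitrogen, 1 oxygen; one five-membered aromatic ring with 2 hetero atoms, one six-membered aromatic ring of carbon only) in place of a group of 9 heavy atoms (7 carbon, 2 nitrogen; one five-membered aromatic ring with 1 hetero atom, one six-membered aromatic ring with 1 hetero atom), on an aromatic carbon. Among the measured compounds shown here, the one measured step, a 1.6-fold higher number from compound 1 to compound 3 (0.21 log units; within the scatter), concerns the chain alone and leaves the aromatic group untouched. For the measured compounds named here, it gives no direct guide to this change, and no measured compound varies this group. The size of the step is thus poorly bounded, and any direction rests on the structural change alone. A move to a lower number in this assay, beyond the scatter, is the tentative expectation, and no change at all remains possible. The expected step is a 4.7-fold lower number from compound 1 to compound 4 (0.67 log units; beyond the scatter), held with low confidence. For compound 4 the estimated value is 4000 nM, with an expected range from 300 nM to 25000 nM.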

Compound 4, half-maximal inhibitory concentration: > 100000 nM
Compound 4 gave a limit, no number; the forecaster's own chance of this, stated with the estimate: 5%; middle value at least 25-fold (1.39 log units) away from the limit.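

In this assay, the aromatic group on the shared core proves to be a place where the read-out responds beyond the scatter, which the chain step alone did not show: a 1.6-fold higher number from compound 1 to compound 3 (0.21 log units; within the scatter) stays within the scatter, whereas 2-amino-1,3-benzoxazol-5-yl on the aromatic carbon, with the chain held, gives an at least 5.2-fold higher number from compound 1 to compound 4 (0.72 log units; beyond the scatter). Going by these compounds, the change is in the direction of weaker inhibition, and its true size remains unknown, since compound 4 gave a limit and not a number: the limit of > 100000 nM in this assay, at which 1 of the 4 values shown sits. The entering and leaving groups differ both in their rings and in their hydrogen-bond acceptors, and this single pair does not separate those differences.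

On these data alone, whether a methyl group or a plain hydrogen in place of the amino group of 2-amino-1,3-benzoxazol-5-yl would bring the value back into the measurable range remains open. Also open is whether a shorter or longer chain would change the outcome with this aromatic group, as the only chain comparison shown carries the other aromatic group and compound 2 has no number.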